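This account rests on a few compounds, and the source may have more. Where it says the series, first, only, none or still open, it means among the compounds named here.

Among the measured compounds shown here, compound 1 `CCCCCCCCCCc1ccc(-c2noc(CCCN)n2)cc1` gives 67% in an assay on HeLa cells for inhibition of sphingosine-1-phosphate transporter SPNS2 (Mus musculus), read by LC-MS, tested at 2 uM (on this read-out lower numbers stand for less inhibition and higher numbers for more inhibition at the one concentration tested (going by the name of the read-out)), the higher of the two numbers measured so far. Compound 2 `CCCCCCCCCCc1ccc(-c2noc([C@@H]3CCC[C@@H](N)C3)n2)cc1` gives 13% in this assay, and the step of a number 54 percentage points lower from compound 1 to compound 2 (beyond the scatter) concerns the amine-bearing group rather than the long chain. Compound 3 `CCCCCCCCCc1ccc(-c2noc(CCCN)n2)cc1` differs from compound 1 by hydrogen in place of methyl on a saturated chain carbon, nine bonds along the chain from an aromatic carbon. For the measured compounds named here, no measured step touches the length of this chain, so the change is expected to stay within the usual scatter, with no clear direction. Compound 3 is therefore estimated at 62%, between 40% and 80%. The expected step is a number 5 percentage points lower from compound 1 to compound 3 (within the scatter).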

Compound 3, a percentage reported as inhibition, at one concentration (the size of the read-out at that concentration, not a potency): 61%
Compound 3: the middle estimate sits 1 percentage points above what was measured; low and high end bracket the measured number.
By their numbers in this assay, from the lowest: compound 2; then compounds 3 and 1 (each within the scatter of the next).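

Hydrogen in place of methyl on a saturated chain carbon, nine bonds along the chain from an aromatic carbon, gives a number 6 percentage points lower from compound 1 to compound 3 (within the scatter) in this assay. Among the compounds shown here, this is the first measured point on the long chain, and here the chain gives up this one carbon with no change that stands out from the scatter. No evidence at hand offers an explanation for this result.

On these data alone, what a much shorter chain, a longer chain or an ether oxygen within the chain would do remains open. A single step of one carbon does not settle how much of the chain's length matters.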